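A few compounds are considered here, and "the series" means these few. Any claim that something is new, unique, unknown or untested is made for them only; others in the source may bear on it.

Measured so far:
- compound 1 `CCCCC[Se]c1nc(NCc2ccc(SC)cc2)c2ccccc2n1` gives 40400 nM in a functional assay on HTB-54 cells (Homo sapiens) for cytotoxicity, read by MTT assay, with a stated time of 72 h; a lower number here means a stronger inhibitor of growth, a higher number a weaker inhibitor of growth
- compound 2 `CSc1nc(NCCCCc2ccccc2)c2ccccc2n1` gives > 100000 nM in this assay

The value for compound 2 is a limit of the assay, not a number: compound 2 sits at the limit of > 100000 nM in this assay, at which 1 of the 2 values shown sits. Only compound 1 has a measured value in this assay. Compound 3 `CSc1nc(NCCCCCO)c2ccccc2n1` differs from compound 2 in one place: hydroxymethyl in place of phenyl on a saturated chain carbon, four bonds along the chain from a nitrogen on an aromatic ring. No step between measured compounds covers this change, so nothing shown sets its size or direction. Starting from a limit, the step expected is a step that the limit leaves unreadable from compound 2 to compound 3, nothing beyond the usual scatter in this assay. Compound 3 is estimated at 120000 nM, with a likely range from 40000 nM to 300000 nM, and a strong chance that the assay again reports only a limit rather than a number.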

Compound 3, concentration for 50% growth inhibition: 31400 nM
Compound 3: the middle estimate sits 3.8-fold (0.58 log units) above what was measured, outside the stated range (below it).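

Replacing phenyl with hydroxymethyl on this saturated chain carbon gives an at least 3.1-fold lower number from compound 2 to compound 3 (0.50 log units; beyond the scatter). The aromatic ring at the end of the chain is therefore not required for a measurable effect in this assay, and compound 3, with a smaller group that brings a hydrogen-bond donor and acceptor, gives 31400 nM. Compound 2 gives only a limit, so this step has a floor but no exact size: the limit of > 100000 nM in this assay, at which 1 of the 3 values shown sits.

On these data alone, it remains open whether the change in growth inhibition follows from losing phenyl or from gaining hydroxymethyl, a question that a chain ending in a plain methyl, an amine or a carboxylic acid could help to separate. Compound 1 differs from compound 3 in more than one place, so their values say nothing about this change.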